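The compounds below may be only part of what the source reports. "The series", "measured", "known", "first", "only" and "open" are said of these compounds alone.

Measured compounds:
Compound 1, `Cc1ccc(-c2cc(CCC(=O)N3CCN(Cc4ccc(C(C)(C)C)cc4)CC3)nn2-c2ccc(Cl)nn2)cc1`, gives 2800 nM in an assay on isolated protein for inhibition of Polyunsaturated fatty acid 5-lipoxygenase (Homo sapiens), read by HPLC, with a stated time of 15 min, in the presence of a further agent that is not named here; a higher number here means a weaker inhibitor, a lower number a stronger inhibitor.
Compound 2, `Cc1ccc(-c2cc(CCC(=O)N3CCN(Cc4ccc(C(C)(C)C)cc4)CC3)nn2-c2ccc(Cl)cc2)cc1`, gives 2900 nM in this assay.

Within the data shown here, compound 2 has the higher of the two numbers, but its one neighbour is compound 1, and the step from one to the other, a 1.0-fold higher number from compound 1 to compound 2 (0.02 log units; within the scatter), lies within the scatter, so the two compounds cannot be told apart on these figures.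

Compound 3, `CC(C)(C)c1ccc(CN2CCN(C(=O)CCc3cc(-c4ccc(F)cc4)n(-c4ccc(Cl)cc4)n3)CC2)cc1`, is the next compound in the series. It differs from compound 2 in one place: fluoro in place of methyl on an aromatic carbon. Among the measured compounds shown here, no measured step touches this position. For the measured compounds named here, the only step that has been measured is the exchange of the ring on the nitrogen, which from compound 1 to compound 2 gave a 1.0-fold higher number from compound 1 to compound 2 (0.02 log units; within the scatter), and it says nothing about the fluoro for methyl swap. With nothing to build on, the expectation is that compound 3 behaves about like compound 2, with a step of no change at the digits printed from compound 2 to compound 3 (within the scatter) in this assay. The estimate for compound 3 is therefore 2900 nM, within a range of 1000 nM to 8500 nM.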

Compound 3, half-maximal inhibitory concentration: 2600 nM
Compound 3: the middle estimate sits 1.1-fold (0.05 log units) above what was measured; low and high end bracket the measured number.
By their numbers in this assay, from the lowest: compounds 3, 1 and 2 (each within the scatter of the next).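

Among these compounds, this is the first reading at this position, the aromatic carbon para to a large group, and going from 4-methylphenyl to 4-fluorophenyl in this assay gives a 1.1-fold lower number from compound 2 to compound 3 (0.05 log units; within the scatter) on the printed figures. Methyl and fluoro each count as one heavy atom with no hydrogen-bond donors or acceptors, and on these numbers compound 2 and compound 3 cannot be told apart, so this particular exchange shows no measurable effect on the read-out. No further measurement is available to account for this result.

The compounds shown leave open whether a different kind of group at this place, such as an amine, a carboxylic acid or a longer chain, would also leave the number within the scatter or would move it clearly in either direction. They also leave open whether the exchange of methyl for fluoro would read the same with the 6-chloropyridazin-3-yl ring of compound 1 on the aromatic nitrogen in place of 4-chlorophenyl.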